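This account rests on a few compounds, and the source may have more. Where it says the series, first, only, none or still open, it means among the compounds named here.

Working notes on the series. For the measured compounds named here, in a functional assay on KYSE-450 cells (Homo sapiens) for inhibition, read by MTT assay, with a stated time of 48 h (a higher number here means a weaker inhibitor, a lower number a stronger inhibitor), compound 1 (`C/C=C/C(=O)N(Cc1ccc(OC)c(N)c1)c1cc(OC)c(OC)c(OC)c1`) gives 310 nM, the lowest of the three numbers so far. The other two lie well beyond the scatter from it: compound 2 (`COc1ccc(N(Cc2cc(OC)c(OC)c(OC)c2)C(=O)CCl)cc1O`) gives 29800 nM and compound 3 (`COc1ccc(CNc2cc(OC)c(OC)c(OC)c2)cc1C`) gives 73800 nM. Neither of these differs from compound 1 in one place only, so the three values describe a spread and do not isolate the effect of any single group.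

The next compound to read is compound 4 (`C/C=C/C(=O)N(Cc1ccc(OC)c(F)c1)c1cc(OC)c(OC)c(OC)c1`), which keeps the core of compound 1 and has fluoro in place of amino on an aromatic carbon, ortho to a methoxy group and meta to a large group: fluoro in place of amino on an aromatic carbon. The same difference reads as 3-amino-4-methoxyphenyl to 3-fluoro-4-methoxyphenyl.

Going by the values given here, no measured pair shows this change, and no measured compound carries the fluoro group, so the expectation is weakly founded. Among the compounds with values here, the only close anchor is compound 1 at 310 nM. A moderate loss of potency in this assay is expected, meaning a higher number, probably beyond the scatter, though a step within it cannot be excluded. The estimated step is a 4.8-fold higher number from compound 1 to compound 4 (0.68 log units; beyond the scatter). For compound 4 the expected value is about 1500 nM, with an estimated range of 300 nM to 8000 nM.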

Compound 4, half-maximal inhibitory concentration: 1400 nM
Compound 4: middle estimate off by 1.1-fold (0.03 log units), on the high side; the measured number falls inside the stated range.
By their numbers in this assay, from the lowest: compound 1; then compound 4; then compound 2; then compound 3.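

In this assay, for the compounds shown here, this pair gives the first step that isolates a single change: a 4.5-fold higher number from compound 1 to compound 4 (0.65 log units; beyond the scatter), beyond the scatter, so on this aromatic carbon, ortho to a methoxy group and meta to a large group, fluoro in place of amino weakens the compound, something the earlier spread of values could not show. The step is modest, and compound 4 still gives 1400 nM, so activity in this assay does not depend entirely on the amino group, although the hydrogen-bond donor and acceptor counted on amino are absent from fluoro and this one pair cannot tell whether that difference matters. No measurement at hand accounts for the size or direction of the step.

As far as these compounds go, it remains open whether the step reflects the departure of amino or the arrival of fluoro, and a chloro group, a nitrile or a dimethylamino group at this position on the core of compound 1 would help separate the two. Going by these compounds alone, with only this one pair, it also remains open whether the same change would give a similar step on any other core.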